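Series notes: anilino in place of 4-methoxyphenyl

The source may report more compounds than this note shows. Statements on the series, on what has been measured and on what is new or still open speak of the compounds shown alone.

Measured so far in a functional assay on PC-3 cells (Homo sapiens) for antiproliferative activity, read by MTT assay, with a stated time of 48 h; a higher number here means a weaker inhibitor, a lower number a stronger inhibitor:
compound 1, `COc1cc(-c2nnc(SCC(=O)c3ccc(C)cc3)n2N)cc(OC)c1OC`, 31300 nM
compound 2, `COc1cc(-c2nnc(SCC(=O)c3ccc(F)cc3)n2N)cc(OC)c1OC`, at the limit > 100000 nM
compound 3, `COc1ccc(C(=O)CSc2nnc(-c3cc(OC)c(OC)c(OC)c3)n2N)cc1`, 97900 nM

The value of compound 2 is a limit of this assay, not a number (the limit of > 100000 nM in this assay, at which 1 of the 3 values shown sits). Among the two numbers, compound 3 stands highest; its nearest neighbour is compound 1, and the step of a 3.1-fold higher number from compound 1 to compound 3 (0.50 log units; beyond the scatter) lies beyond the scatter. The step of an at least 1.0-fold lower number from compound 2 to compound 3 (0.00 log units; that floor lies within the scatter) cannot be separated from the scatter.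

Compound 4 is `COc1cc(-c2nnc(SCC(=O)Nc3ccccc3)n2N)cc(OC)c1OC`; it differs from compound 3 by anilino in place of 4-methoxyphenyl on a carbonyl carbon. Among the compounds with values here, every measured step changes the substituent on an aromatic carbon, and none touches the carbonyl carbon, so no measured step bears directly on this change. In this assay compound 4 is expected near compound 3, the step of a 1.1-fold lower number from compound 3 to compound 4 (0.04 log units; within the scatter) being expected to stay within the scatter. Compound 4 is thus estimated at 90000 nM, with a range from 30000 nM to 300000 nM.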

Compound 4, half-maximal inhibitory concentration: 37900 nM
The estimate for compound 4 lay 2.4-fold (0.38 log units) above the measured number, and the stated range covers the measured number.
By their numbers in this assay, from the lowest: compounds 1 and 4 (each within the scatter of the next); then compound 3. At a limit, above all of these: compound 2.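

The carbonyl carbon now has a measured change of its own, and the outcome depends on the group replaced: in this assay, anilino in place of 4-methoxyphenyl gives a 2.6-fold lower number from compound 3 to compound 4 (0.41 log units; beyond the scatter), while anilino in place of 4-methylphenyl gives a 1.2-fold higher number from compound 1 to compound 4 (0.08 log units; within the scatter). Anilino in place of 4-fluorophenyl gives only a floor, an at least 2.6-fold lower number from compound 2 to compound 4 (0.42 log units; beyond the scatter). Compound 2 stands at a limit, not a number: the limit of > 100000 nM in this assay, at which 1 of the 4 values shown sits.

As far as these compounds go, it remains open whether methyl, fluoro or methoxy on the anilino ring would move the number as they do on the aryl ketones. From the compounds shown here alone, how a saturated amine such as piperidine would compare on the carbonyl carbon is also open.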